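A few compounds are considered here, and "the series" means these few. Any claim that something is new, unique, unknown or untested is made for them only; others in the source may bear on it.

In a functional assay on HL-60 cells (Homo sapiens) for cytotoxicity, read by MTT assay, with a stated time of 4 days (on this read-out higher numbers stand for weaker inhibition and lower numbers for stronger inhibition), compound 1 `C=C1C[C@]23C[C@@]1(O)CC[C@@H]2c1cccc(C)c1[C@@H]3Cn1cc(-c2ccc(Br)cc2)nn1` gives only a limit, > 20000 nM. Compound 2 `C=C1C[C@]23C[C@@]1(O)CC[C@H]2c1ccc(OS(=O)(=O)c2ccc(C)cc2)c(C)c1[C@@H]3Cn1cc(-c2ccc(C)cc2)nn1` likewise gives only a limit in this assay, > 20000 nM. Compound 3 `Cc1c(O)ccc2c1[C@H](Cn1cc(-c3ccc(F)cc3)nn1)[C@@]13CC(=O)[C@@](C)(CC[C@@H]21)C3`, the starting point of the step followed here, also reaches only a limit in this assay, > 20000 nM. Compound 3 therefore stands exactly where the other two measured compounds stand: all three values sit at the limit of > 20000 nM in this assay, at which 3 of the 3 values shown sit, and none of them separates from another, so no order among compounds 1, 2 and 3 can be read from these numbers. Among the measured compounds shown here, no step between measured compounds that differ in a single place has been recorded, so this assay offers no measured change from which the effect of a small substitution could be gauged.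

Compound 4 `Cc1ccc(-c2cn(C[C@H]3c4c(ccc(O)c4C)[C@@H]4CC[C@@]5(C)C[C@]43CC5=O)nn2)cc1` differs from compound 3 by a single change: methyl in place of fluoro on an aromatic carbon. With every measured value resting at a limit, nothing in the numbers points in either direction for such a change. The step that the limit leaves unreadable from compound 3 to compound 4 is accordingly expected to amount to no shift beyond the usual scatter. Compound 4 is thus expected to give 30000 nM in this assay, with a range from 10000 nM to 100000 nM, and it is expected that the assay will again report a limit rather than a number.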

Compound 4, half-maximal inhibitory concentration: > 20000 nM
Compound 4 ended at the assay's limit; the forecaster's own chance of this, stated with the estimate: 85%; the middle value is on the limit's open side.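

In this assay compound 4 gives only a limit, > 20000 nM. Compound 3 gives a limit as well, so no step can be read between compound 3 and compound 4: the limit of > 20000 nM in this assay, at which 4 of the 4 values shown sit.

The compounds shown leave open which structural change, if any, would bring a measurable value in this assay.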